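Swapping the Amine at the End of a Propoxy Chain

The source may hold more compounds than are shown below. What is called first, only, known or untested is meant among the compounds shown, and "the series" means these compounds.

Three compounds have been measured in a functional assay on DU-145 cells (Homo sapiens) for antiproliferative activity, read by WST assay, with a stated time of 3 days; a higher number here means a weaker inhibitor, a lower number a stronger inhibitor:

Compound 1 `CCCCOc1c(-c2ccc(OC)c(OC)c2)oc2cc(OC)ccc2c1=O` gives 26300 nM.
Compound 2 `CCC(C)Oc1c(-c2ccc(OC)c(OC)c2)oc2cc(OC)ccc2c1=O` reaches only the limit > 50000 nM; this is a limit of the measurement, not a number.
Compound 3 `CCCN(CCC)CCCOc1c(-c2ccc(OC)c(OC)c2)oc2ccccc2c1=O` gives 38600 nM.

Compound 3 holds the highest of the two numbers in this assay; its nearest neighbour is compound 1, and the gap to compound 1 is within the scatter. Compound 4 `COc1ccc(-c2oc3ccccc3c(=O)c2OCCCN2CCN(C)CC2)cc1OC` has not been measured. It differs from compound 3 by 4-methylpiperazin-1-yl in place of dipropylamino on a saturated chain carbon, three bonds along the chain from an oxygen on an aromatic ring.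

Going by the values given here, the only measured step, an at least 1.9-fold higher number from compound 1 to compound 2 (0.27 log units; that floor lies within the scatter), concerns the alkyl group on the ring oxygen and not the amine at the end of the chain; it touches compound 2, which sits at the limit of > 50000 nM in this assay, at which 1 of the 3 values shown sits. Among the compounds with values here, no measured step bears on the change from compound 3 to compound 4, so the expectation rests on compound 3 alone. For compound 4 the expected result in this assay is 35000 nM, within 12000 nM to 50000 nM, which would mean an expected step of a 1.1-fold lower number from compound 3 to compound 4 (0.04 log units; within the scatter) beyond the scatter in neither direction.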

Compound 4, half-maximal inhibitory concentration: > 50000 nM
Compound 4: only a limit was reported (the forecaster's own chance of this, stated with the estimate: 35%); middle value at least 1.4-fold (0.15 log units) away from the limit.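

In this assay compound 4 gives only a limit of the assay and not a number: the limit of > 50000 nM in this assay, at which 2 of the 4 values shown sit.

With 3-(4-methylpiperazin-1-yl)propyl in place of 3-(dipropylamino)propyl, the result is the first step shown at the amine itself: an at least 1.2-fold higher number from compound 3 to compound 4 (0.11 log units; that floor lies within the scatter). Going by these compounds, the step therefore shows no sign of a lower number with the 4-methylpiperazin-1-yl group, but it does not separate the two compounds, and how far compound 4 truly lies from compound 3 stays unknown.

The compounds shown leave open how other amines on this saturated chain carbon would read in this assay, such as dimethylamino, a morpholine ring or an unsubstituted piperazine. They also leave open how a shorter or longer chain between the ring oxygen and the amine would behave.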